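The source may report more compounds than this note shows. Statements on the series, on what has been measured and on what is new or still open speak of the compounds shown alone.

Among the compounds with values here, compound 1, with the structure `Fc1ccccc1C1=NC(c2ccccc2)CO1`, is one of two compounds measured in a physicochemical assay for lipophilicity; a lower number here means a more polar compound, a higher number a more lipophilic compound. In this assay compound 1 gives 3.51, the lower of the two numbers recorded so far. The other measured compound is compound 2, with the structure `Clc1ccc(C2=NC(c3ccccc3)CO2)cc1`; in this assay compound 2 gives 4.48, a number that lies beyond the usual scatter above that of compound 1. No further comparison between these two is drawn here, since they differ in more than one place.

The step followed here leads from compound 1 to compound 3, whose structure is `c1ccc(Oc2ccccc2C2=NC(c3ccccc3)CO2)cc1` and which has not yet been measured in this assay. The difference between the two structures is phenoxy in place of fluoro on an aromatic carbon. A group of seven heavy atoms, including a second aromatic ring, takes the place of a single fluorine on the shared core.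

On this basis the step from compound 1 to compound 3 is expected to be large and upward, roughly a number 1.89 log units higher from compound 1 to compound 3 (beyond the scatter). Compound 3 is therefore estimated to give about 5.4 in this assay, with a plausible range from 4.9 to 5.9.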

Compound 3, partition coefficient: 5.61
The estimate for compound 3 lay 0.21 log units below the measured number; the measured number falls inside the stated range.
By their numbers in this assay, from the lowest: compound 1; then compound 2; then compound 3.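

Exchanging fluoro for phenoxy on this aromatic carbon, ortho to a large group, gives a number 2.10 log units higher from compound 1 to compound 3 (beyond the scatter) in this assay. Within the data shown here, this is the first comparison in the set in which only one place changes, so it is the first direct sign that the group at this position can shift the reading by a large amount, while the rest of the molecule stays the same. The entering phenoxy group brings an oxygen, a six-membered aromatic ring and more heavy atoms all at once, and no measurement offered here separates their contributions or explains the step.

Still open, from the compounds shown here alone, is how a smaller ether such as methoxy, or an amine or a carboxylic acid, would read at this same aromatic carbon, and with them whether the number follows the size of the group or some other feature of it. Also open, going by these compounds, is whether the same exchange of fluoro for phenoxy would give a step of similar size at another carbon of that ring or on a different core: a single step sets no rule.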